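The source may hold more compounds than are shown below. What is called first, only, known or untested is meant among the compounds shown, and "the series" means these compounds.

Measured so far:
compound 1 `CC1CN(Cc2cccc(C(=N)N)c2)C(=O)N(C2CCN(Cc3ccccc3)CC2)C1` — 13500 nM
compound 2 `CS(=O)(=O)NC1CN(CC2CCN(Cc3ccccc3)CC2)C(=O)N(c2cccc(C(=N)N)c2)C1` — 330 nM

In an assay on isolated protein for inhibition of Suppressor of tumorigenicity 14 protein (Homo sapiens), read by fluorescence (on this read-out lower numbers stand for stronger inhibition and higher numbers for weaker inhibition), compound 1 gives the higher of the two numbers; compound 2, built on a different core, gives 330 nM, a gap beyond the usual scatter. Compound 3 `CC1CN(Cc2ccc(C(=N)N)cc2)C(=O)N(C2CCN(Cc3ccccc3)CC2)C1` differs from compound 1 only in a group of 9 heavy atoms (7 carbon, 2 nitrogen; one six-membered aromatic ring of carbon only) in place of a group of 9 heavy atoms (7 carbon, 2 nitrogen; one six-membered aromatic ring of carbon only), on a saturated chain carbon bound to an amide-type nitrogen in a ring. Within the data shown here, no measured pair shows this rearrangement, so its size is uncertain. A moderate shift toward a lower number in this assay is expected, a 3.9-fold lower number from compound 1 to compound 3 (0.59 log units; beyond the scatter), with a step within the scatter also possible. Compound 3 is therefore estimated at 3500 nM, expected between 600 nM and 20000 nM.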

Compound 3, inhibition constant: 15400 nM
Compound 3: middle estimate off by 4.4-fold (0.64 log units), on the low side; the range from low to high includes it.
By their numbers in this assay, from the lowest: compound 2; then compounds 1 and 3 (each within the scatter of the next).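

In this assay, the rearrangement of the group of 9 heavy atoms on this saturated chain carbon gives a 1.1-fold higher number from compound 1 to compound 3 (0.06 log units; within the scatter). Among these compounds, this is the first comparison that differs in one place, and on the shared core the two joinings of the same atoms cannot be told apart in this assay. No supporting data bear on this result. Open, on these data alone, is whether a primary amine or a carboxylic acid at this place on the shared core would give a number beyond the scatter. Also open, as far as these compounds go, is whether the same rearrangement gives a comparable step on the core of compound 2.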